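A few compounds are considered here, and "the series" means these few. Any claim that something is new, unique, unknown or untested is made for them only; others in the source may bear on it.

Two compounds from this set have been examined in a functional assay on PC-3 cells (Homo sapiens) for cytotoxicity, read by MTT assay, with a stated time of 48 h (on this read-out lower numbers stand for stronger inhibition and higher numbers for weaker inhibition), and neither one yielded an actual number. Compound 1, `COc1ccc(/C=C/C(=O)/C=C/c2cc3ccccc3nc2Cl)c(OC)c1`, reached only the limit of > 10000 nM. Compound 2, `COc1ccc(/C=C/C(=O)/C=C/c2cc3ccccc3nc2Oc2ccc(Br)cc2)cc1`, likewise stopped at the limit of > 10000 nM. Within the data shown here, compound 2 thus stands exactly where every value so far stands, namely at the limit of > 10000 nM in this assay, at which 2 of the 2 values shown sit, with no measured potency beneath it. The next compound, compound 3, `COc1ccc(/C=C/C(=O)/C=C/c2cc3ccccc3nc2Oc2ccc(Br)cc2)c(OC)c1`, differs from compound 2 in a single place: methoxy in place of hydrogen on an aromatic carbon. Among the measured compounds shown here, no step between two measured compounds is available, so the size of this change cannot be read from a neighbouring pair. Both measured compounds, compound 1 among them with the 2,4-dimethoxyphenyl already present, sit at the limit of > 10000 nM in this assay, at which 2 of the 2 values shown sit. The step that the limit leaves unreadable from compound 2 to compound 3 is therefore expected to be none beyond the scatter. Compound 3 is estimated to give 20000 nM, within 8000 nM to 60000 nM, most likely again only as a limit.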

Compound 3, half-maximal inhibitory concentration: > 10000 nM
Compound 3: no number, only a limit; the forecaster's own chance of this, stated with the estimate: 80%; the middle value is on the limit's open side.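

Compound 3, like compound 1 and compound 2, ends at a limit and not at a number, so no step among these compounds can be read: the limit of > 10000 nM in this assay, at which 3 of the 3 values shown sit.

The compounds shown leave open how potent any of them really is, and what difference, if any, methoxy in place of hydrogen makes.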